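Changing the ester tail: expected cytotoxicity of compound 3

The compounds below may be only part of what the source reports. "The series", "measured", "known", "first", "only" and "open" are said of these compounds alone.

Measured compounds:
- compound 1, `CCCCC(=O)OCCc1c(-c2ccccc2Cl)c2cc(Cl)ccc2[nH]c1=O`: 200000 nM
- compound 2, `CC12CCC(C(=O)OCCc3c(-c4ccccc4Cl)c4cc(Cl)ccc4[nH]c3=O)(OC1=O)C2(C)C`: > 1800000 nM

For the measured compounds named here, in an ADME assay on HepG2 2.2.15 cells (Homo sapiens) for cytotoxicity (on this read-out lower numbers stand for higher toxicity in this test and higher numbers for lower toxicity in this test), compound 1 gives 200000 nM, the only plain number among the values shown. For compound 2 this assay gives only a limit, > 1800000 nM, so its true value is not known. Going by the values given here, the one measured step, an at least 9.0-fold higher number from compound 1 to compound 2 (0.95 log units; beyond the scatter), swaps the butyl on the carbonyl carbon for a much larger bicyclic group and ends at the limit, (the limit of > 1800000 nM in this assay, at which 1 of the 2 values shown sits), so the step can only be given as a lower bound.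

Compound 3, `COc1cccc(/C=C/C(=O)OCCc2c(-c3ccccc3Cl)c3cc(Cl)ccc3[nH]c2=O)c1`, has not yet been measured. It differs from compound 1 by 2-(3-methoxyphenyl)ethenyl in place of butyl on a carbonyl carbon. As in the step to compound 2, a larger group takes the place of the butyl on the same carbonyl carbon, though here it is an aromatic ring with a double bond rather than a saturated bicycle. On that basis a higher number, meaning lower toxicity, is expected, but with uncertainty about whether compound 3 will also reach the limit. Compound 3 is therefore estimated at 600000 nM, between 200000 nM and 1800000 nM, which corresponds to an expected step of a 3.0-fold higher number from compound 1 to compound 3 (0.48 log units; beyond the scatter).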

Compound 3, half-maximal cytotoxic concentration: > 1300000 nM
Compound 3 was reported as a limit (the forecaster's own chance of this, stated with the estimate: 40%); at least 2.1-fold (0.33 log units) between middle value and limit.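

The butyl on the carbonyl carbon of compound 1 has now been replaced by a second, quite different large group, 2-(3-methoxyphenyl)ethenyl, and the change gives an at least 6.5-fold higher number from compound 1 to compound 3 (0.81 log units; beyond the scatter), which means lower toxicity in this test. A rise at this position therefore no longer rests on the saturated bicyclic group of compound 2 alone: a group with an aromatic ring and a double bond goes the same way, and among these three compounds none goes against the pattern that a larger group in place of butyl gives a higher number. In this assay compound 3 gives only a limit and not a true number: the limit of > 1300000 nM in this assay, at which 1 of the 3 values shown sits.

The step between compound 2 and compound 3 cannot be read, as both values are limits, which leaves the two large groups unranked and the full size of each rise over compound 1 unknown. On these data alone, it also remains open whether a simple longer carbon chain on the same carbonyl carbon would raise the number as well, or whether a ring is needed, and how a tail carrying an amine or a carboxylic acid would behave.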